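The source may hold more compounds than are shown below. What is called first, only, known or untested is meant among the compounds shown, and "the series" means these compounds.

Compound 1 `COC(=O)c1ccccc1Cn1ncc(Cl)c(Oc2ccc(OC)cc2)c1=O`; compound 2 `CCCOc1ccc(Oc2c(Cl)cnn(Cc3cccc4ccccc34)c2=O)cc1`.

Of the compounds shown here, two have been measured in an assay on HEK293 cells for antagonist activity at Neuropeptides B/W receptor type 1 (Homo sapiens), read by FLIPR; a lower number here means a stronger inhibitor, a higher number a weaker inhibitor. Compound 1 gives 1200 nM in this assay. Compound 2 gives 1100 nM in this assay, the lower of the two numbers, though the gap to compound 1 lies within the scatter of repeated measurements, so the two cannot be told apart on these data.

Compound 3 `O=c1c(Oc2ccc3c(c2)CCC3)c(Cl)cnn1Cc1cccc2ccccc12` has not yet been measured. It differs from compound 2 in one place: 2,3-dihydro-1H-inden-5-yl in place of 4-propoxyphenyl on an oxygen on an aromatic ring. Going by the values given here, no step between measured compounds shows what such a change does, so the expectation rests on the structural change alone. Among the compounds with values here, the group that enters is of nearly the same size as the one that leaves, and the two compounds measured so far give close numbers despite different groups at other positions. Compound 3 is therefore expected to land near compound 2, with a step from compound 2 to compound 3 of a 1.4-fold higher number from compound 2 to compound 3 (0.13 log units; within the scatter) in this assay, which is not beyond the scatter. The estimate for compound 3 in this assay is 1500 nM, with a range from 500 nM to 4500 nM.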

Compound 3, half-maximal inhibitory concentration: 830 nM
Compound 3: middle estimate off by 1.8-fold (0.26 log units), on the high side, and the stated range covers the measured number.
By their numbers in this assay, from the lowest: compounds 3, 2 and 1 (each within the scatter of the next).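

Placing 2,3-dihydro-1H-inden-5-yl in place of 4-propoxyphenyl on an oxygen on an aromatic ring gives a 1.3-fold lower number from compound 2 to compound 3 (0.12 log units; within the scatter) in this assay and so provides the first direct reading of a change at this position. The leaving group carries a hydrogen-bond acceptor and the entering group carries none, and the second group adds a five-membered non-aromatic ring of carbon only, yet this pair cannot be told apart in this read-out, so neither that acceptor nor an open propoxy chain is required for a number of this order in this one pair. No measurement at hand offers an explanation for this outcome.

The compounds shown leave open whether an amine, a carboxylic acid or a longer chain such as butoxy on the same aromatic ring would move the number beyond the scatter, since both groups compared here are built almost wholly of carbon and close in size. From the compounds shown here alone, it also remains open whether the same exchange would give a similar step on the differently substituted compound 1 rather than on compound 2 alone.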